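The compounds below may be only part of what the source reports. "The series", "measured", "known", "first", "only" and "open" are said of these compounds alone.

Series notes on the step from compound 1 to compound 4.

Compound 1 `Fc1ccc(C2(c3ccc(F)cc3)CNC(c3cccc(Br)c3)=N2)cc1` gives 4.8 nM in an assay on LM cells for displacement of a labelled ligand from Neuropeptide Y receptor type 5 (Homo sapiens) (a lower number here means a stronger inhibitor, a higher number a weaker inhibitor), the lowest of the two numbers recorded, with compound 2 `OCc1cccc(C2=NC(c3ccc(F)cc3)(c3ccc(F)cc3)CN2)c1` nearest at 59 nM. Compound 3 `CN(C)c1cccc(C2=NC(c3ccc(F)cc3)(c3ccc(F)cc3)CN2)c1` gives only a limit, > 1000 nM, in this assay; this is the limit of > 1000 nM in this assay, at which 1 of the 3 values shown sits.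

The measured steps all replace the bromo on the aromatic carbon of compound 1: a 12-fold higher number from compound 1 to compound 2 (1.09 log units; beyond the scatter), and an at least 200-fold higher number from compound 1 to compound 3 (2.31 log units; beyond the scatter), while an at least 16-fold higher number from compound 2 to compound 3 (1.22 log units; beyond the scatter) sets the two replacements against each other. In every case the change away from bromo gives a higher number, and the step size differs with what enters.

Compound 4 `Fc1ccc(C2(c3ccc(F)cc3)CNC(c3cccnc3)=N2)cc1` has not been measured in this assay. Its change from compound 1 is pyridin-3-yl in place of 3-bromophenyl on a carbon with a double bond to nitrogen. The measured steps bear on it only in part: they keep the phenyl ring and vary its substituent, whereas here the bromine leaves and a ring nitrogen enters. The steps from compound 1 to compounds 2 and 3 suggest a weaker inhibitor is expected once the bromo is gone, with a step somewhere around an 8.3-fold higher number from compound 1 to compound 4 (0.92 log units; beyond the scatter) considered most likely. For compound 4 the number expected in this assay is 40 nM, with the range 10 nM to 200 nM.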

Compound 4, half-maximal inhibitory concentration: 7.2 nM
The estimate for compound 4 lay 5.6-fold (0.74 log units) above the measured number; the whole stated range lies above it.
By their numbers in this assay, from the lowest: compounds 1 and 4 (each within the scatter of the next); then compound 2. At a limit, above all of these: compound 3.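

In this assay, among the compounds shown here, the earlier compounds all kept the phenyl ring and showed only what happens when its bromo is replaced; here the whole 3-bromophenyl group is exchanged for pyridin-3-yl, and compound 1 and compound 4 stand within the scatter of each other: a 1.5-fold higher number from compound 1 to compound 4 (0.18 log units; within the scatter). So a bromo is not required at this carbon of the shared core, and compound 4 goes against the earlier reading that every departure from compound 1 gives a higher number, while the two substituted phenyl compounds still fit it, as an 8.2-fold lower number from compound 2 to compound 4 (0.91 log units; beyond the scatter) and an at least 130-fold lower number from compound 3 to compound 4 (2.14 log units; beyond the scatter) show. The second of those steps is only a bound, since the value of compound 3 is a limit and not a number: the limit of > 1000 nM in this assay, at which 1 of the 4 values shown sits.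

No measurement shown bears on why pyridin-3-yl and 3-bromophenyl sit within the scatter of each other at this position. Still open, as far as these compounds go, is how plain phenyl, pyridin-2-yl or pyridin-4-yl would read here, and whether the pyridin-3-yl ring of compound 4 keeps its standing once it carries a bromo, a hydroxymethyl or an amine.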